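This account rests on a few compounds, and the source may have more. Where it says the series, first, only, none or still open, it means among the compounds named here.

Compound 3 `O=c1c2cnn(-c3ccc(F)cc3)c2ncn1CC1(O)CCN(Cc2ccc(Cl)cc2Cl)CC1` gives 3300 nM in an assay on Sf21 cells for inhibition of ubiquitin carboxyl-terminal hydrolase 7 (Homo sapiens), read by spectrophotometry, with stated times of 30 min and 2 h; on this read-out higher numbers stand for weaker inhibition and lower numbers for stronger inhibition. Going by the values given here, only two numbers exist in this assay: compound 1 `O=c1c2cnn(-c3ccc(F)cc3)c2ncn1CC1(O)CCN(Cc2ccccc2Br)CC1` gives 3100 nM, and the two lie within the scatter of each other, as a 1.1-fold higher number from compound 1 to compound 3 (0.03 log units; within the scatter) shows. Compound 2 `O=c1c2cnn(-c3ccc(F)cc3)c2ncn1CC1(O)CCN(Cc2c(Cl)cccc2Cl)CC1` has no reported result in this assay, its entry reading "not determined" (no result reported). Compound 4 `O=c1c2cnn(-c3ccc(F)cc3)c2ncn1CC1(O)CCN(Cc2ccc(Br)cc2Cl)CC1` differs from compound 3 in one place: bromo in place of chloro on an aromatic carbon. Among the compounds with values here, the single measured step that bears on this, the one from compound 1 to compound 3, also exchanged halogens on this ring and produced no shift beyond the scatter. The expected step is therefore no change at the digits printed from compound 3 to compound 4 (within the scatter), essentially none. Compound 4 is estimated at about 3300 nM, with a range from 1500 nM to 7500 nM.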

Compound 4, half-maximal inhibitory concentration: 1900 nM
For compound 4 the middle estimate is 1.7-fold (0.24 log units) above the measured one, and the stated range covers the measured number.
By their numbers in this assay, from the lowest: compounds 4, 1 and 3 (each within the scatter of the next).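

In this assay, going by these compounds alone, the chloro group para to the large group was exchanged for bromo alone, with nothing else on the ring altered, and this gave a 1.7-fold lower number from compound 3 to compound 4 (0.24 log units; within the scatter) and so isolated this one atom for the first time. Set against the 2-bromophenyl compound, the 4-bromo-2-chlorophenyl group gave a 1.6-fold lower number from compound 1 to compound 4 (0.21 log units; within the scatter) and likewise stayed within the scatter, so these halogen patterns are not separated here. No supporting evidence bears on this result. Going by these compounds, what a methoxy group or a carboxylic acid on this carbon would do remains open, as does whether any group there could shift the number beyond the scatter.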